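A few compounds are considered here, and "the series" means these few. Any claim that something is new, unique, unknown or untested is made for them only; others in the source may bear on it.

Compound 1 `CS(=O)(=O)c1ccc(C(=O)N2CCC(C(=O)N3CCc4ccccc43)CC2)cc1[N+](=O)[O-]`: > 60000 nM in an assay on isolated protein for inhibition of thyroid hormone receptor alpha (Homo sapiens), read by fluorescence polarization; on this read-out higher numbers stand for weaker inhibition and lower numbers for stronger inhibition
Compound 2 `CC(C)N(C(=O)C1CCN(C(=O)c2ccc(S(C)(=O)=O)c([N+](=O)[O-])c2)CC1)C(C)C`: > 60000 nM in this assay

Compound 2 stands only as a limit in this assay: its value of > 60000 nM marks the edge of what the measurement can report, not a number. The same holds for compound 1 at > 60000 nM. Within the data shown here, the single measured step, a step that the two limits leave unreadable from compound 1 to compound 2, therefore cannot be read, because both of its ends sit at the limit of > 60000 nM in this assay, at which 2 of the 2 values shown sit. Compound 3 `CS(=O)(=O)c1ccc(C(=O)N2CCC(C(=O)N3CCc4ccccc4C3)CC2)cc1[N+](=O)[O-]` differs from compound 2 by 1,2,3,4-tetrahydroisoquinolin-2-yl in place of diisopropylamino on a carbonyl carbon. With no readable step to guide the direction, compound 3 is expected to stay at the limit too, so the expected step is a step that the limit leaves unreadable from compound 2 to compound 3. The estimate for compound 3 is 100000 nM, ranging from 30000 nM to 400000 nM.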

Compound 3, half-maximal inhibitory concentration: > 60000 nM
Compound 3: no number, only a limit; the forecaster's own chance of this, stated with the estimate: 85%; the middle value does not contradict the limit.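

Compound 3 also gives only a limit, so its steps from compound 1 and compound 2 cannot be read: the limit of > 60000 nM in this assay, at which 3 of the 3 values shown sit. The compounds shown leave open whether any group on this carbonyl carbon gives a measurable value in this assay.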